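The source may hold more compounds than are shown below. What is called first, only, known or untested is meant among the compounds shown, and "the series" means these compounds.

Series notes. Three compounds sharing the core of compound 1 `CCOC(=O)C1=Cc2ccccc2OC1(OCc1cn(CC(=O)NC2CCCCC2)nn1)C(F)(F)F` have been run in a functional assay on DU-145 cells (Homo sapiens) for inhibition, read by MTT assay, with a stated time of 24 h; on this read-out higher numbers stand for weaker inhibition and lower numbers for stronger inhibition. Compound 1 gives 10200 nM, the lowest of the three numbers. Compound 2 `Cc1ccc(-c2cc(COC3(C(F)(F)F)Oc4ccccc4C=C3C(=O)O)on2)cc1` gives 41400 nM in this assay, a higher number that lies beyond the scatter relative to compound 1. Compound 3 `CCOC(=O)C1=Cc2ccccc2OC1(OCc1cc(-c2ccc(Br)cc2)no1)C(F)(F)F` gives 71700 nM in this assay, also beyond the scatter from compound 1; the values of compound 2 and compound 3 lie within the scatter of each other. Among the measured compounds shown here, no two measured compounds differ in a single place, so no measured single-point step exists within the set.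

The next entry is compound 4 `CCOC(=O)C1=Cc2ccccc2OC1(OCc1cn(-c2cccc(C(F)(F)F)c2)nn1)C(F)(F)F`, which differs from compound 1 in one place: 3-(trifluoromethyl)phenyl in place of (cyclohexylcarbamoyl)methyl on an aromatic nitrogen. Nothing measured speaks to this change directly. Given that compound 1 gives 10200 nM and the measured set spans a narrow band, the step from compound 1 to compound 4 is expected at a 1.5-fold higher number from compound 1 to compound 4 (0.17 log units; within the scatter), within the scatter or at most a small move toward a higher number. Compound 4 is accordingly estimated at 15000 nM in this assay, with a range from 4000 nM to 55000 nM.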

Compound 4, half-maximal inhibitory concentration: > 150000 nM
Compound 4 was reported as a limit (the forecaster's own chance of this, stated with the estimate: 10%); middle value at least 10-fold (1.00 log units) from the limit.
By their numbers in this assay, from the lowest: compound 1; then compounds 2 and 3 (each within the scatter of the next). At a limit, above all of these: compound 4.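

The aromatic nitrogen now has its first measured single-place change: in this assay, replacing (cyclohexylcarbamoyl)methyl with 3-(trifluoromethyl)phenyl gives an at least 14-fold higher number from compound 1 to compound 4 (1.16 log units; beyond the scatter). Compound 4 is reported only as a limit, > 150000 nM. Heavy-atom count is the same on both sides of the step, so that count alone does not set the read-out at this position, and the step is only a bound: the limit of > 150000 nM in this assay, at which 1 of the 4 values shown sits.

The change replaces the non-aromatic ring with an aromatic one and removes the amide in the same step, so the compounds shown cannot separate these features or the role of the trifluoromethyl group. Open comparisons at this nitrogen include unsubstituted phenyl, (phenylcarbamoyl)methyl and a cyclohexyl ring attached directly.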